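A 2-hydroxyethyl group on the chain of compound 2

This account rests on a few compounds, and the source may have more. Where it says the series, first, only, none or still open, it means among the compounds named here.

In a functional assay, read by fluorescence and spectrophotometry, with a stated time of 1 h (on this read-out higher numbers stand for an effect only at larger amounts of compound and lower numbers for an effect already at smaller amounts), compound 2 (`CCCCCS(=O)(=O)/C=C/c1ccc(O)c(O)c1`) gives 8100 nM. Compound 1 (`CCCCCCS(=O)(=O)/C=C/c1ccc(O)c(O)c1`) gives 7300 nM, within the scatter of compound 2. The change to compound 3 (`O=S(=O)(/C=C/c1ccc(O)c(O)c1)CCCCCCCO`) is 2-hydroxyethyl in place of hydrogen on a saturated chain carbon, five bonds along the chain from a sulfonyl sulfur. Going by the values given here, the only measured step bearing on it is a 1.1-fold higher number from compound 1 to compound 2 (0.05 log units; within the scatter), made at the same chain carbon. Among the compounds with values here, no measured compound carries a 2-hydroxyethyl group, so this step is a weak guide and the range stays wide. The expected step in this assay is a 1.0-fold lower number from compound 2 to compound 3 (0.01 log units; within the scatter), which means none beyond the scatter. For compound 3 the estimated value is 8000 nM, with an expected range from 3500 nM to 18000 nM.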

Compound 3, half-maximal effective concentration: 5900 nM
The estimate for compound 3 lay 1.4-fold (0.13 log units) above the measured number, within the range that was stated.
By their numbers in this assay, from the lowest: compounds 3, 1 and 2 (each within the scatter of the next).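

In this assay, 2-hydroxyethyl in place of hydrogen gives a 1.4-fold lower number from compound 2 to compound 3 (0.14 log units; within the scatter), and hydroxymethyl in place of hydrogen, on the saturated chain carbon six bonds along the chain from the sulfonyl sulfur, gives a 1.2-fold lower number from compound 1 to compound 3 (0.09 log units; within the scatter). Where the earlier compounds compared only hydrogen with methyl, these steps show that a chain carrying an oxygen also stays within the scatter of both compounds with plain chains. No measurement on hand accounts for this result. Going by these compounds, whether an amine or a carboxylic acid in place of 2-hydroxyethyl, or a longer chain, would move the number beyond the scatter stays open.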